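A few compounds are considered here, and "the series" means these few. Any claim that something is new, unique, unknown or untested is made for them only; others in the source may bear on it.

Measured so far:
compound 1, `Nc1ncnc2c1ncn2[C@@H]1O[C@H](CNCc2ccc(-c3cc(C(F)(F)F)ccc3Cl)o2)[C@@H](O)[C@H]1O`, 32400 nM
compound 2, `Nc1ncnc2c1ncn2[C@@H]1O[C@H](CNCc2ccc(OCC(=O)Nc3nccs3)cc2)[C@@H](O)[C@H]1O`, 90400 nM

Both compounds share a common core and differ only in the group carried on the chain beyond it. In an assay for inhibition of histone-lysine N-methyltransferase, H3 lysine-79 specific (Homo sapiens), read by scintillation counting, with a stated time of 1 h, in the presence of a further agent that is not named here (a lower number here means a stronger inhibitor, a higher number a weaker inhibitor), compound 2 gives the higher of the two numbers, with compound 1 giving a lower number, and that gap lies beyond the scatter of the assay, so compound 2 is the weaker inhibitor of this pair.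

Compound 3, `Nc1ncnc2c1ncn2[C@@H]1O[C@H](CNCc2ccc(OCc3ccccc3)cc2)[C@@H](O)[C@H]1O`, is not yet measured. Compared with compound 2 it carries the change (phenyl in place of (1,3-thiazol-2-yl)carbamoyl on a saturated chain carbon bound to an oxygen on an aromatic ring). The chain on the aromatic oxygen is thus shortened and simplified, and the donor and acceptors of the departing group are lost.

For the measured compounds named here, no measured pair here shows this exact change, so the size of the step can only be estimated. Going by the values given here, since the benzyl group brings an aromatic ring like the one that sits in compound 1, a modest move toward a lower number is expected, and the step is estimated at a 2.3-fold lower number from compound 2 to compound 3 (0.35 log units; beyond the scatter). Compound 3 is expected to give about 40000 nM in this assay, somewhere between 12000 nM and 130000 nM.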

Compound 3, half-maximal inhibitory concentration: 120000 nM
Compound 3: middle estimate off by 3.0-fold (0.48 log units), on the low side, and the stated range covers the measured number.
By their numbers in this assay, from the lowest: compound 1; then compounds 2 and 3 (each within the scatter of the next).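

In this assay, putting phenyl in place of (1,3-thiazol-2-yl)carbamoyl, on a saturated chain carbon bound to an oxygen on an aromatic ring, gives a 1.3-fold higher number from compound 2 to compound 3 (0.12 log units; within the scatter), so compound 2 and compound 3 cannot be told apart in this test. At this place, then, the five-membered aromatic ring with its hetero atoms, the double bond outside the ring, and the hydrogen-bond donor and acceptors of the departing group can all give way to a plain six-membered carbon ring with no readable change in the number. Nothing on hand offers a reason for this result.

What the compounds shown leave open is whether any group at this place can move the number beyond the scatter, since this one exchange, large as it is in structure, does not. A carboxylic acid or an amine on the phenyl ring, or a longer chain between the aromatic oxygen and that ring, would test this further.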